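Swapping a cyclohexyl for a fluorophenoxy on an anilide

The source may report more compounds than this note shows. Statements on the series, on what has been measured and on what is new or still open speak of the compounds shown alone.

Measured so far:
Compound 1 `COc1ccc(-c2cc(=O)c3c(OC)cc(OC)cc3n2S(=O)(=O)c2ccc([N+](=O)[O-])cc2)cc1`: "not determined" (no result reported)
Compound 2 `COc1cc(OC)c2c(=O)cc(C(=O)Nc3ccc(C4CCCCC4)cc3)[nH]c2c1`: "not determined" (no result reported)
Compound 3 `COc1cc(OC)c2c(=O)cc(C(=O)Nc3cc(C(F)(F)F)ccc3Oc3ccccc3OC)[nH]c2c1`: 10800 nM

For the measured compounds named here, in a functional assay on SEM cells (Homo sapiens) for antiproliferative activity, with a stated time of 72 h (a higher number here means that more compound is needed for the effect, a lower number that less compound is needed), compound 2 has no number at all, and the same holds for compound 1, so compound 2 stands nowhere on the scale yet; the only anchor is compound 3, which in this assay gives 10800 nM. Compound 4 `COc1cc(OC)c2c(=O)cc(C(=O)Nc3ccc(Oc4ccc(F)cc4)cc3)[nH]c2c1` keeps the shared core and the amide of compound 2 but carries 4-fluorophenoxy in place of cyclohexyl on an aromatic carbon. Going by the values given here, with no measured step to lean on, no size or direction can be expected beyond the usual scatter, and the weak result of compound 3 suggests a modest number. For compound 4 the expected value in this assay is 6000 nM, with a plausible range from 1000 nM to 30000 nM.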

Compound 4, half-maximal effective concentration: > 50000 nM
Compound 4 ended at the assay's limit; the forecaster's own chance of this, stated with the estimate: 30%; middle value at least 8.3-fold (0.92 log units) away from the limit.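

No step can be read between compound 2 and compound 4. Compound 4 gives > 50000 nM, which is a limit and not a number. The compounds shown leave open how swapping cyclohexyl for 4-fluorophenoxy alters potency.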